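Swapping one acetylated ring on an amide-type nitrogen

The compounds below may be only part of what the source reports. "The series", "measured", "known", "first", "only" and "open" are said of these compounds alone.

Three related compounds have been measured in a physicochemical assay for solubility, read by spectrophotometry, measured as kinetic solubility, at pH 8, tested at 500 uM; on this read-out higher numbers stand for higher solubility and lower numbers for lower solubility. Compound 1 `Cn1ccc2ccc(-c3cc(Nc4ccccc4S(=O)(=O)Nc4cncnc4)cc4nccnc34)cc21` gives 254 ug/mL, compound 2 `Cn1cc(CNC(=O)c2ccncc2Nc2cc(-c3ccc4ccn(C)c4c3)c3nccnc3c2)cn1` gives 127 ug/mL, and compound 3 `CC(=O)N1CCC(NC(=O)c2ccncc2Nc2cc(-c3ccc4ccn(C)c4c3)c3nccnc3c2)CC1` gives 213 ug/mL. Compound 3 therefore stands within the scatter of both others, meaning that repeat measurements alone could produce gaps of this size. The unmeasured compound 4 `CC(=O)N1CCOC(CNC(=O)c2ccncc2Nc2cc(-c3ccc4ccn(C)c4c3)c3nccnc3c2)C1` differs from compound 3 in one place, on an amide-type nitrogen: (4-acetylmorpholin-2-yl)methyl in place of 1-acetylpiperidin-4-yl on an amide-type nitrogen. Among the compounds with values here, only one measured step changes that same place, a 1.7-fold higher number from compound 2 to compound 3 (0.22 log units; within the scatter). There, 1-acetylpiperidin-4-yl replaced (1-methyl-1H-pyrazol-4-yl)methyl, and the difference stayed within the scatter. Within the data shown here, no measured step links compound 1 to the others, and no measured compound carries the (4-acetylmorpholin-2-yl)methyl group, so this evidence is thin. On that basis, no change beyond the scatter is expected in this assay, and the expected step is a 1.1-fold lower number from compound 3 to compound 4 (0.03 log units; within the scatter). For compound 4, the estimated value is 200 ug/mL, with an expected range of 115 ug/mL to 300 ug/mL.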

Compound 4, solubility: 268 ug/mL
Beside the measured number, compound 4's estimate is 1.3-fold (0.13 log units) below it, and the stated range covers the measured number.
By their numbers in this assay, from the lowest: compounds 2, 3, 1 and 4 (each within the scatter of the next, the first and the last beyond it).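

In this assay, putting (4-acetylmorpholin-2-yl)methyl in place of 1-acetylpiperidin-4-yl on the amide-type nitrogen gives a 1.3-fold higher number from compound 3 to compound 4 (0.10 log units; within the scatter) and leaves these two acetylated rings indistinguishable on this read-out. Within the data shown here, putting 4-acetylmorpholin-2-yl in place of 1-methyl-1H-pyrazol-4-yl on the saturated chain carbon bound to that nitrogen gives a 2.1-fold higher number from compound 2 to compound 4 (0.32 log units; beyond the scatter) as the first step at this position to clear the scatter, though only modestly. Nothing measured here explains that difference.

Still open, on these data alone, is whether the difference between compound 2 and compound 4 follows the morpholine ring or the acetyl on it. A morpholine ring with a free amine, or with methylsulfonyl in place of acetyl, would help separate the two.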